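Working notes: chloro to methoxy at compound 4

The source may report more compounds than this note shows. Statements on the series, on what has been measured and on what is new or still open speak of the compounds shown alone.

Measured so far in a functional assay on HT-1080 cells (Homo sapiens) for cytotoxicity, read by MTT assay, with a stated time of 72 h (a higher number here means a weaker inhibitor, a lower number a stronger inhibitor), are these values.
- compound 1 `COc1cccc(/C=C2\CCC/C(=C\c3cccc(Cl)c3)C2=O)c1OC` gives 10300 nM
- compound 2 `COc1cccc(/C=C2\CCC/C(=C\c3cc(OC)c(OC)c(OC)c3)C2=O)c1OC` gives 2300 nM
- compound 3 `COc1ccc(/C=C2\CCC/C(=C\c3ccccc3Cl)C2=O)cc1OC` gives 6800 nM

Compound 3 sits within the scatter of compound 1 and its number is higher than that of compound 2, a gap beyond the scatter. Compound 4 `COc1ccccc1/C=C1\CCC/C(=C\c2ccc(OC)c(OC)c2)C1=O` is unmeasured. Against compound 3 it has methoxy in place of chloro on an aromatic carbon, ortho to a large group. Within the data shown here, no measured pair isolates this change. Compound 2 carries no chloro and gives 2300 nM, so a slight downward lean is expected. The expected size is a 1.4-fold lower number from compound 3 to compound 4 (0.13 log units; within the scatter) and thus no step beyond the scatter in this assay is foreseen. For compound 4 the estimated value is 5000 nM (expected range 2000 nM to 12000 nM).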

Compound 4, half-maximal inhibitory concentration: 8100 nM
For compound 4 the middle estimate is 1.6-fold (0.21 log units) below the measured one, and the stated range covers the measured number.
By their numbers in this assay, from the lowest: compound 2; then compounds 3, 4 and 1 (each within the scatter of the next).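

In this assay, among these compounds, the exchange of 2-chlorophenyl for 2-methoxyphenyl, on an aromatic carbon ortho to a large group, gives the first single-change pair (a 1.2-fold higher number from compound 3 to compound 4 (0.08 log units; within the scatter)), a step within the scatter. At this position, chloro and methoxy are therefore not told apart by this read-out. Nothing available accounts for this result. As far as these compounds go, whether an amine or a carboxylic acid at this position would give a different number remains open. So does whether the same exchange would give a similar step elsewhere on the shared core.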